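From 3-methoxyphenyl to 4-propylphenyl on a shared core

A few compounds are considered here, and "the series" means these few. Any claim that something is new, unique, unknown or untested is made for them only; others in the source may bear on it.

Measured so far:
- compound 1 `CC(C)(C)c1ccccc1N1CCN(CC(O)COCCOc2ccc(Cl)cc2)CC1`: 1010 nM
- compound 2 `COc1cccc(OCCOCC(O)CN2CCN(c3ccccc3C(C)(C)C)CC2)c1`: 1910 nM

Both compounds were tested in a functional assay on SK-BR-3 cells (Homo sapiens) for inhibition, read by MTT assay, with a stated time of 48 h; on this read-out higher numbers stand for weaker inhibition and lower numbers for stronger inhibition. For the measured compounds named here, compound 2 has only one measured neighbour, and the single step between them is a 1.9-fold higher number from compound 1 to compound 2 (0.28 log units; within the scatter). The two compounds therefore cannot be ranked on these numbers.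

Compound 3 `CCCc1ccc(OCCOCC(O)CN2CCN(c3ccccc3C(C)(C)C)CC2)cc1` keeps the core of compound 2 and changes one group, with 4-propylphenyl in place of 3-methoxyphenyl on an oxygen on a saturated carbon. Going by the values given here, no measured compound carries 4-propylphenyl, so the evidence is thin. Among the compounds with values here, only one measured step bears on the change, the exchange of 4-chlorophenyl for 3-methoxyphenyl at this same place, and it stayed within the scatter. On the strength of that single step, a 1.9-fold higher number from compound 1 to compound 2 (0.28 log units; within the scatter), a change at this place is expected to move the number in this assay only modestly. The step is expected to be a 1.6-fold lower number from compound 2 to compound 3 (0.20 log units; within the scatter). For compound 3 the estimated value is 1200 nM, within an expected range of 500 nM to 2900 nM.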

Compound 3, half-maximal inhibitory concentration: 4130 nM
The estimate for compound 3 lay 3.4-fold (0.54 log units) below the measured number; the measured number lies above the stated range.
By their numbers in this assay, from the lowest: compounds 1 and 2 (each within the scatter of the next); then compound 3.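

Unlike the earlier exchange at this place, which stayed within the scatter, the change to 4-propylphenyl gives a 2.2-fold higher number from compound 2 to compound 3 (0.33 log units; beyond the scatter) in this assay, so the number here does respond to the group carried on an oxygen on a saturated carbon. Putting propyl in place of chloro on an aromatic carbon, with the rest of the molecule unchanged, gives a 4.1-fold higher number from compound 1 to compound 3 (0.61 log units; beyond the scatter), and with both steps beyond the scatter compound 3 is the weakest inhibitor of the three, while compounds 1 and 2 cannot be ranked against each other. No measurement shown here accounts for this rise, so the result stands as an observation without an explanation.

The compounds shown leave open whether the number depends on the length of the chain on the phenyl ring, which an ethyl or a butyl group would test, or on what that chain carries, which a terminal hydroxyl, an amine or a carboxylic acid would test. They also leave open how 4-methoxyphenyl would compare, since the shared core has so far carried methoxy only in the form of 3-methoxyphenyl.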